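The source may hold more compounds than are shown below. What is called first, only, known or untested is meant among the compounds shown, and "the series" means these compounds.

Compound 1 `Nc1ncc(Br)c2c1ncn2[C@@H]1C[C@H](O)[C@@H](O)[C@H]1O`: > 8000 nM
Compound 2 `Nc1ncc(I)c2c1ncn2[C@@H]1C[C@H](O)[C@@H](O)[C@H]1O`: 100000 nM

In an ADME assay on Vero cells (Chlorocebus sabaeus) for cytotoxicity, read by microscopy (a lower number here means that less compound is tolerated, a higher number that more compound is tolerated), compound 1 gives > 8000 nM; this is a limit of the assay, not a number. In this assay, within the data shown here, compound 2 gives 100000 nM, the only number among the two values. The step that the limit leaves unreadable from compound 1 to compound 2 cannot be sized because of the limit of > 8000 nM in this assay, at which 1 of the 2 values shown sits.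

Compound 3 `Nc1ncc(Cl)c2c1ncn2[C@@H]1C[C@H](O)[C@@H](O)[C@H]1O` differs from compound 2 by chloro in place of iodo on an aromatic carbon. Among the measured compounds shown here, no measured step gives a readable size for a halogen exchange, so no step beyond the scatter is expected, no change at the digits printed from compound 2 to compound 3 (within the scatter). Compound 3 is therefore estimated at 100000 nM, between 30000 nM and 300000 nM.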

Compound 3, minimum cytotoxic concentration: > 200000 nM
Compound 3 gave a limit, no number; the forecaster's own chance of this, stated with the estimate: 40%; middle value at least 2.0-fold (0.30 log units) away from the limit.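

Among these compounds, with chloro in place of iodo on an aromatic carbon, para to an amino group, this assay gives the first halogen exchange with a readable size, an at least 2.0-fold higher number from compound 2 to compound 3 (0.30 log units; that floor lies within the scatter). This is only a floor, so it sets no order between the two compounds. The steps from compound 1 cannot be read: the limit of > 8000 nM in this assay, at which 1 of the 3 values shown sits.

Where compound 3 truly lies stays open: the limit of > 200000 nM in this assay, at which 1 of the 3 values shown sits. How an amine or a nitrile on this same carbon would compare with the halogens also remains open.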